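Swapping the aryl ether of a thromboxane synthase inhibitor

A few compounds are considered here, and "the series" means these few. Any claim that something is new, unique, unknown or untested is made for them only; others in the source may bear on it.

Among the measured compounds shown here, compound 2, with the structure `Cc1ccc(C#N)c(OC(C)(C)C2OCC(C/C=C\CCC(=O)O)C(c3cccnc3)O2)c1`, is one of two compounds measured in an assay for inhibition of Thromboxane-A synthase (Homo sapiens), using microsomes (on this read-out lower numbers stand for stronger inhibition and higher numbers for weaker inhibition), where it gives 50 nM. Compound 1, with the structure `N#Cc1ccccc1C1OCC(C/C=C\CCC(=O)O)C(c2cccnc2)O1`, gives 54 nM in this assay; the two values sit within the scatter of each other, so neither can be called the stronger inhibitor on these numbers. The unmeasured compound 3, with the structure `CC(C)(Oc1ccccc1[N+](=O)[O-])C1OCC(C/C=C\CCC(=O)O)C(c2cccnc2)O1`, keeps the shared core of compound 2 and changes only the aryl ether: 2-nitrophenyl in place of 2-cyano-5-methylphenyl on an oxygen on a saturated carbon. For the measured compounds named here, no measured pair shows how this assay responds to such a swap, so the step is expected to be small and without a clear direction: from compound 2 to compound 3 the expected change in this assay is a 1.4-fold higher number from compound 2 to compound 3 (0.15 log units; within the scatter). Compound 3 is therefore expected to give about 70 nM in this assay, within a range from 25 nM to 200 nM.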

Compound 3, half-maximal inhibitory concentration: < 10 nM
Compound 3 was reported as a limit; the forecaster's own chance of this, stated with the estimate: 5%; at least 7.0-fold (0.84 log units) between middle value and limit.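

The aryl ether on an oxygen on a saturated carbon turns out to be a place where this assay responds clearly: putting 2-nitrophenyl in place of 2-cyano-5-methylphenyl gives an at least 5.0-fold lower number from compound 2 to compound 3 (0.69 log units; beyond the scatter). Both groups have the same heavy-atom count and one six-membered aromatic ring, so by that count this gain comes without a larger group. The value of compound 3 is a limit and not a number, so the step has only a lower bound: the limit of < 10 nM in this assay, at which 1 of the 3 values shown sits.

The nitrile and the methyl leave together in this swap, so the compounds shown cannot tell whether one of them or the entering nitro group accounts for the step. On these data alone, it also remains open whether 2-aminophenyl or 2-carboxyphenyl in this place would keep the number as low.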